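Swapping methoxy for propylamino on compound 2

The source may report more compounds than this note shows. Statements on the series, on what has been measured and on what is new or still open speak of the compounds shown alone.

Compound 1 `CCOC(=O)c1ccc(-c2nn(Cc3ccccn3)c3ccccc23)cc1` gives > 10000 nM as a limit
Compound 2 `COC(=O)c1ccc(-c2nn(Cc3ccccc3)c3ccccc23)cc1` gives > 10000 nM as a limit

Both readings come from a functional assay on cells (Platelet, Homo sapiens) for inhibition (a lower number here means a stronger inhibitor, a higher number a weaker inhibitor), and neither is an exact number. Compound 2 therefore has no precise standing: its > 10000 nM is a limit of the assay. The whole picture so far is the limit of > 10000 nM in this assay, at which 2 of the 2 values shown sit, and no more.

Compound 3 `CCCNC(=O)c1ccc(-c2nn(Cc3ccccc3)c3ccccc23)cc1` has propylamino in place of methoxy on a carbonyl carbon and so turns methoxycarbonyl to propylcarbamoyl. Within the data shown here, no measured pair shows what such a change does. A modest shift towards stronger inhibition in this assay is expected, with a real chance that the reading stays at the limit. This expectation rests on compound 2 with its limit of > 10000 nM and on little else. The estimated change is a number no higher from compound 2 to compound 3 (the limit leaves the size open) in this expectation. For compound 3 the expected value is 10000 nM with an estimated range from 2000 nM to 30000 nM in repeated measurements.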

Compound 3, half-maximal inhibitory concentration: > 10000 nM
Compound 3: only a limit was reported (the forecaster's own chance of this, stated with the estimate: 55%); the middle value sits exactly at the limit.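

No step can be read from compound 2 to compound 3, since both readings are limits and not exact numbers: the limit of > 10000 nM in this assay, at which 3 of the 3 values shown sit.

The compounds shown leave open whether propylamino in place of methoxy changes inhibition at all, and which change to the shared core would give an exact reading.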